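This account rests on a few compounds, and the source may have more. Where it says the series, first, only, none or still open, it means among the compounds named here.

In a physicochemical assay for solubility, at pH 7.4 (a higher number here means a more soluble compound, a lower number a less soluble compound), compound 2 (`NS(=O)(=O)c1ccc(SCCCO)c(Cl)c1`) gives 280 ug/mL, within the scatter of compound 1 (`CC(C)(O)CCSc1ccc(S(N)(=O)=O)cc1`) at 400 ug/mL. Compound 3 (`NS(=O)(=O)c1ccc(S(=O)(=O)CCCO)c(C(=O)O)c1`) gives 53000 ug/mL, a much higher number and well beyond the scatter. Compound 4 (`COC(=O)c1cc(S(N)(=O)=O)ccc1SCCCO`) has methoxycarbonyl in place of chloro on an aromatic carbon of compound 2 (methoxycarbonyl in place of chloro on an aromatic carbon). Within the data shown here, no measured pair shows this change alone, and compound 3 differs from compound 2 in more than one place, so it is no direct guide. Starting from compound 2 at 280 ug/mL, no shift beyond the scatter is expected in this assay. The expected step is a 1.1-fold higher number from compound 2 to compound 4 (0.03 log units; within the scatter). For compound 4 the estimate is 300 ug/mL, with an expected range from 100 ug/mL to 900 ug/mL.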

Compound 4, solubility: 1300 ug/mL
Beside the measured number, compound 4's estimate is 4.3-fold (0.64 log units) below it; the measured number lies above the stated range.
By their numbers in this assay, from the lowest: compounds 2 and 1 (each within the scatter of the next); then compound 4; then compound 3.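

In this assay, methoxycarbonyl in place of chloro on this aromatic carbon, ortho to the (3-hydroxypropyl)sulfanyl group, gives a 4.6-fold higher number from compound 2 to compound 4 (0.67 log units; beyond the scatter). Among these compounds, this is the first step in the set that changes one place only, and it shows that the group at this position can move the read-out beyond the scatter. Nothing shown here explains the rise.

Still open, from the compounds shown here alone, is how a nitrile or a primary amide at this carbon would read. So is whether the same swap gives a similar step with a longer chain in place of the (3-hydroxypropyl)sulfanyl group.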